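Aryl sulfonamide variation in a leukaemia cell growth assay

The source may report more compounds than this note shows. Statements on the series, on what has been measured and on what is new or still open speak of the compounds shown alone.

Compound 1 `O=S(=O)(Nc1ccccc1Cl)c1ccc(-c2cnc(C3CC3)o2)cc1` and compound 2 `O=S(=O)(Nc1cccc(Cl)c1)c1ccc(-c2cnc(C3CC3)o2)cc1` share the same core and differ only in the aryl group on the sulfonamide nitrogen. In a functional assay on cells (leukaemia cell line, Homo sapiens) for inhibition, read by sulforhodamine B assay, with a stated time of 48 h (on this read-out lower numbers stand for stronger inhibition of growth and higher numbers for weaker inhibition of growth), compound 1 gives 49700 nM, and compound 2 gives 54200 nM. The step of a 1.1-fold higher number from compound 1 to compound 2 (0.04 log units; within the scatter) shows that exchanging one chlorophenyl for the other leaves the number within the scatter. Within the data shown here, compound 2 holds the higher of the two numbers so far, with compound 1 nearest and within the scatter, so no order between the two can be stated.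

Compound 3 `O=S(=O)(Nc1ccc(F)cc1F)c1ccc(-c2cnc(C3CC3)o2)cc1` is not yet measured. The change from compound 2 is 2,4-difluorophenyl in place of 3-chlorophenyl on a sulfonamide nitrogen. Among the measured compounds shown here, no measured pair exchanges a chlorinated aryl group for a fluorinated one, so the only step that bears on this change is a 1.1-fold higher number from compound 1 to compound 2 (0.04 log units; within the scatter), which itself stayed within the scatter. Nothing in the measured data points to a shift beyond the scatter. Compound 3 is therefore expected at 52000 nM, with a range of 26000 nM to 104000 nM. The estimated step of a 1.0-fold lower number from compound 2 to compound 3 (0.02 log units; within the scatter) is expected to remain within the scatter.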

Compound 3, concentration for total growth inhibition: 66100 nM
Beside the measured number, compound 3's estimate is 1.3-fold (0.10 log units) below it; the measured number falls inside the stated range.
By their numbers in this assay, from the lowest: compounds 1, 2 and 3 (each within the scatter of the next).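

Working notes on the aryl group on the sulfonamide nitrogen: in this assay, replacing a chlorophenyl with 2,4-difluorophenyl gives a 1.2-fold higher number from compound 2 to compound 3 (0.09 log units; within the scatter) and a 1.3-fold higher number from compound 1 to compound 3 (0.12 log units; within the scatter). The earlier pair exchanged only one chlorophenyl for another, whereas these two steps change both the halogen and the substitution pattern on the ring, and neither moves the number beyond the scatter, so compounds 1, 2 and 3 cannot be ranked and the three aryl groups remain indistinguishable in this read-out. No supporting data bear on why these changes leave the number within the scatter.

On these data alone, all three groups on the sulfonamide nitrogen are halogen-bearing phenyl rings, so it remains open whether this place tolerates any aryl group in this assay or whether a basic amine or a carboxylic acid on the ring, or a longer alkyl chain in place of the ring, would move the number beyond the scatter. The shared core is also unchanged across the compounds shown, so the contribution of the rest of the molecule to the growth inhibition remains unaddressed.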